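The source may hold more compounds than are shown below. What is called first, only, known or untested is meant among the compounds shown, and "the series" means these compounds.

Measured compounds:
Compound 1 `CCCCCCCCCCCCn1nnc(C(NC(=O)c2c(C(C)C)cccc2C(C)C)c2ccccc2)n1` in an assay on microsomes from liver for inhibition of sterol O-acyltransferase 1 (Rattus norvegicus); on this read-out higher numbers stand for weaker inhibition and lower numbers for stronger inhibition: 810 nM
Compound 2 `CCCCCCCCCCCCn1nnc(C(NC(=O)c2ccc(F)cc2F)c2ccccc2)n1` in this assay: 490 nM

On these two numbers compound 1 stands highest, and its nearest neighbour is compound 2, where a 1.7-fold lower number from compound 1 to compound 2 (0.22 log units; within the scatter) lies within the scatter. Compound 3 `CCCCCCCCCCCCn1nnc(C(NC(=O)c2ccccc2[N+](=O)[O-])c2ccccc2)n1` differs from compound 1 in this way: 2-nitrophenyl in place of 2,6-diisopropylphenyl on a carbonyl carbon. Going by the values given here, the only measured step that bears on it is that exchange at a carbonyl carbon, which stayed within the scatter. For compound 3 no step beyond the scatter is therefore expected in this assay, the estimated change being a 1.2-fold lower number from compound 1 to compound 3 (0.10 log units; within the scatter). Compound 3 is expected to give 650 nM, with a range of 220 nM to 2000 nM.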

Compound 3, half-maximal inhibitory concentration: 240 nM
Beside the measured number, compound 3's estimate is 2.7-fold (0.43 log units) above it, within the range that was stated.
By their numbers in this assay, from the lowest: compound 3; then compounds 2 and 1 (each within the scatter of the next).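

In this assay the group on the carbonyl carbon proves able to move the number beyond the scatter, with a 3.4-fold lower number from compound 1 to compound 3 (0.53 log units; beyond the scatter) and a 2.0-fold lower number from compound 2 to compound 3 (0.31 log units; beyond the scatter) on the exchange to 2-nitrophenyl. The earlier step from 2,6-diisopropylphenyl to 2,4-difluorophenyl had not shown this, so the position is not indifferent to what it carries. No evidence on hand accounts for these steps. The compounds shown leave open whether the nitro group itself matters, and whether 2-aminophenyl or 2-carboxyphenyl on the same carbonyl carbon would keep the lower number.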